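Piperazine tail shortened and lengthened: compound 4 on the shared core

This account rests on a few compounds, and the source may have more. Where it says the series, first, only, none or still open, it means among the compounds named here.

Measured compounds:
compound 1 `CN1CCN(CCCCCn2c3c(c4ccccc42)C(=O)c2c[n+]([O-])c4ccccc4c2C3=O)CC1` gives 1220 nM in a functional assay on HCT-116 cells (Homo sapiens) for cytotoxicity, read by MTT assay, with a stated time of 72 h; a lower number here means a stronger inhibitor, a higher number a weaker inhibitor
compound 2 `CC1(C)OCC(Cn2cc(Cn3c4c(c5ccccc53)C(=O)c3c[n+]([O-])c5ccccc5c3C4=O)nn2)O1` gives 70 nM in this assay
compound 3 `O=C1c2c[n+]([O-])c3ccccc3c2C(=O)c2c1c1ccccc1n2Cc1cn([C@@H]2C[C@H](O)[C@@H](CO)O2)nn1` gives 50 nM in this assay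

Compound 1 has the highest number of the three in this assay; compound 2 and compound 3 both sit far lower, beyond the scatter. For the measured compounds named here, the single measured step, a 1.4-fold lower number from compound 2 to compound 3 (0.15 log units; within the scatter), concerns the group on the aromatic nitrogen and lies within the scatter; it says nothing about the piperazine tail.

Compound 4 `CCCN1CCN(CCCCn2c3c(c4ccccc42)C(=O)c2c[n+]([O-])c4ccccc4c2C3=O)CC1` differs from compound 1 by 4-propylpiperazin-1-yl in place of (4-methylpiperazin-1-yl)methyl on a saturated chain carbon, four bonds along the chain from an aromatic nitrogen. Going by the values given here, no measured step bears on this change; the shared core and the aromatic nitrogen substituent are otherwise the same as in compound 1. For compound 4 no step beyond the scatter is therefore expected, a 1.0-fold lower number from compound 1 to compound 4 (0.01 log units; within the scatter). The number for compound 4 in this assay is estimated at 1200 nM, with a range of 500 nM to 3000 nM.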

Compound 4, half-maximal inhibitory concentration: 790 nM
Estimate against measurement, compound 4: 1.5-fold (0.18 log units) above, and the stated range covers the measured number.
By their numbers in this assay, from the lowest: compounds 3 and 2 (each within the scatter of the next); then compounds 4 and 1 (each within the scatter of the next).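

In this assay, 4-propylpiperazin-1-yl in place of (4-methylpiperazin-1-yl)methyl on a saturated chain carbon, four bonds along the chain from an aromatic nitrogen, gives a 1.5-fold lower number from compound 1 to compound 4 (0.19 log units; within the scatter). This position therefore accepts this exchange of tails without a step beyond the scatter. No measured evidence on this pair accompanies the result.

Going by these compounds, the pair alters the chain and the piperazine substituent together, so the contribution of each stays open. Also open, on these data alone, is how a morpholine or a carboxylic acid would read at the end of this chain.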